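Replacing tert-butylphenyl with dimethylphenyl in compound 1

The source may hold more compounds than are shown below. What is called first, only, known or untested is meant among the compounds shown, and "the series" means these compounds.

Compound 1 `COc1cc(CNC(=S)NCC(COC(=O)C(C)(C)C)Cc2ccc(C(C)(C)C)cc2)c(Br)cc1O` gives 12.8 nM in an assay on CHO cells for displacement of a labelled ligand from transient receptor potential cation channel subfamily V member 1 (Rattus norvegicus) (a lower number here means a stronger inhibitor, a higher number a weaker inhibitor), the lowest of the two numbers shown, though its nearest neighbour compound 2 `COc1cc(CNC(=S)NCC(COC(=O)C(C)(C)C)Cc2ccc(C(C)(C)C)cc2)c(I)cc1O` at 13.3 nM lies within the scatter, as the step of a 1.0-fold higher number from compound 1 to compound 2 (0.02 log units; within the scatter) confirms. Compound 3 `COc1cc(CNC(=S)NCC(COC(=O)C(C)(C)C)Cc2ccc(C)c(C)c2)c(Br)cc1O` differs from compound 1 by 3,4-dimethylphenyl in place of 4-(tert-butyl)phenyl on a saturated chain carbon, three bonds along the chain from an amide-type nitrogen and an oxygen next to a carbonyl group. Within the data shown here, no measured step touches this position, so the only step available, which concerns the halogen, does not bear on it. The change removes two carbons from the ring substituent, and a modest weakening is expected, a 3.9-fold higher number from compound 1 to compound 3 (0.59 log units; beyond the scatter). Compound 3 is therefore estimated at 50 nM, between 15 nM and 200 nM.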

Compound 3, inhibition constant: 19.9 nM
Compound 3: middle estimate off by 2.5-fold (0.40 log units), on the high side; the range from low to high includes it.
By their numbers in this assay, from the lowest: compounds 1, 2 and 3 (each within the scatter of the next).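

In this assay, 3,4-dimethylphenyl takes the place of 4-(tert-butyl)phenyl with a step that stays within the scatter (a 1.6-fold higher number from compound 1 to compound 3 (0.19 log units; within the scatter)). For this pair, then, going from 10 heavy atoms to 8 heavy atoms in this group on the saturated chain carbon leaves the reading unresolved from that of compound 1. Nothing available accounts for this result. The compounds shown leave open how a phenyl ring carrying an amine or a carboxylic acid would read here, or a longer chain in place of the benzyl link. They also leave open whether the same change reads alike with the iodo of compound 2.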